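Working notes: dipropylamino in place of aminomethyl, compound 2 to 3

The source may report more compounds than this note shows. Statements on the series, on what has been measured and on what is new or still open speak of the compounds shown alone.

Measured so far:
- compound 1, `Cc1nc2c(SCc3ccccc3)cccn2c1N`: 0%
- compound 2, `Cc1nc2c(OCc3ccccc3)cccn2c1CN`: 46%

In a functional assay on the whole organism with Rattus norvegicus as the target, at a dose of 40 mg/kg by the intraperitoneal route (on this read-out higher numbers stand for more inhibition at the one dose given (going by the name of the read-out) and lower numbers for less inhibition), compound 2 gives 46%, the higher of the two numbers recorded. For the measured compounds named here, compound 1 gives 0% in this assay, a gap that lies beyond the scatter; the two compounds differ in more than one place, so no single step between them can be read from these numbers.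

Compound 3, `CCCN(CCC)c1c(C)nc2c(OCc3ccccc3)cccn12`, is not yet measured. Relative to compound 2 the change is dipropylamino in place of aminomethyl on an aromatic carbon. Going by the values given here, with only two measured compounds and no single-point step recorded, there is no precedent for this change. It is expected that the step of a number 26 percentage points lower from compound 2 to compound 3 (beyond the scatter) lies toward less inhibition, beyond the scatter. For compound 3 the estimate in this assay is 20%, with a range from 0% to 50%.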

Compound 3, a percentage reported as inhibition, in the whole organism at one dose (the size of the read-out at that dose, not a potency): 60%
Compound 3: middle estimate off by 40 percentage points, on the low side; the measured number lies above the stated range.
By their numbers in this assay, from the lowest: compound 1; then compound 2; then compound 3.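

In this assay, dipropylamino in place of aminomethyl on this aromatic carbon gives a number 14 percentage points higher from compound 2 to compound 3 (beyond the scatter). This position therefore accepts a much larger group, with 7 heavy atoms in place of 2, without loss of inhibition at the one dose given. The hydrogen-bond donor of aminomethyl is also not needed for this level of inhibition, at least in this pair. No measured information accounts for the step.

Size, donor count and the link between the nitrogen and the ring all change together in this single step, so their separate contributions cannot be told apart. From the compounds shown here alone, it remains open how a dimethylamino group, with shorter chains on the same nitrogen, or a piperidine ring at this position would read out.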